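The source may hold more compounds than are shown below. What is called first, only, known or untested is meant among the compounds shown, and "the series" means these compounds.

Measured so far in a functional assay on MDA-MB-231 cells (Homo sapiens) for inhibition, read by sulforhodamine B assay, with a stated time of 72 h; on this read-out lower numbers stand for stronger inhibition of growth and higher numbers for weaker inhibition of growth:
compound 1 `COC1CN(C(=O)/C=C/c2ccncc2-c2ccc3ccccc3c2)C1` — > 10000 nM
compound 2 `Cn1ccc2cc(-c3cnccc3/C=C/C(=O)O)ccc21` — > 10000 nM

In this assay compound 1 gives > 10000 nM, which is a limit of the assay and not a number. In this assay compound 2 gives > 10000 nM, again a limit rather than a measured number. Among the compounds with values here, compound 2 therefore has no place on a scale of numbers here: both values shown sit at the limit of > 10000 nM in this assay, at which 2 of the 2 values shown sit, so no measured step and no spread between compound 1 and compound 2 can be read, and neither can be called weaker or stronger than the other.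

Compound 3 `CNC(=O)/C=C/c1ccncc1-c1ccc2c(ccn2C)c1` differs from compound 2 in one place: methylamino in place of hydroxy on a carbonyl carbon. The change trades carboxy for methylcarbamoyl on the otherwise unchanged core of compound 2. Within the data shown here, no step of this kind has been measured. Compound 1, which also lacks a carboxy, sits at the same limit, and nothing in the numbers points in either direction, so the expected step from compound 2 to compound 3 is a step that the limit leaves unreadable from compound 2 to compound 3, none beyond the scatter. Compound 3 is accordingly estimated at 15000 nM, with a range from 4000 nM to 60000 nM, and is most likely to be reported once more only as a limit.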

Compound 3, concentration for 50% growth inhibition: 8550 nM
Beside the measured number, compound 3's estimate is 1.8-fold (0.24 log units) above it, and the stated range covers the measured number.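

With methylamino in place of hydroxy on the carbonyl carbon, the series gains its first entry in this assay that is a number and not a limit: compound 3 gives 8550 nM. The change from carboxy to methylcarbamoyl on the otherwise unchanged core amounts to an at least 1.1-fold lower number from compound 2 to compound 3 (0.06 log units; that floor lies within the scatter), so the position accepts this exchange, but no gain in growth inhibition can be claimed from it. The true size of the step stays hidden, and only this floor can be stated: the limit of > 10000 nM in this assay, at which 2 of the 3 values shown sit.

Open, as far as these compounds go, is whether the value of compound 3 holds for other groups on the same carbonyl carbon, such as amino, dimethylamino or a longer chain like ethylamino, which would show whether the amide hydrogen or the size of the group carries any weight in this assay. Also open, from the compounds shown here alone, is whether a carbonyl is needed at this place at all, which a basic amine at the end of the 2-(methylcarbamoyl)ethenyl chain's position, or an ester of the carboxy group, could begin to answer.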